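From methylamino to piperidin-3-yl on the shared core

The compounds below may be only part of what the source reports. "The series", "measured", "known", "first", "only" and "open" are said of these compounds alone.

Compound 1 `CCOC(=O)c1cc(NCc2cccnc2)n2ncc(Br)c2n1` gives 2900 nM
Compound 2 `CNc1cc(NCc2cccnc2)n2ncc(Br)c2n1` gives 1200 nM

Going by the values given here, in a functional assay on cells (Homo sapiens), read by thymidine incorporation (a higher number here means a weaker inhibitor, a lower number a stronger inhibitor), compound 2 gives 1200 nM as the lower of the two numbers so far. Compound 3 `Brc1cnn2c(NCc3cccnc3)cc(C3CCCNC3)nc12` carries piperidin-3-yl in place of methylamino on an aromatic carbon. Among the compounds with values here, the one measured step at that same carbon (a 2.4-fold lower number from compound 1 to compound 2 (0.38 log units; beyond the scatter)) was modest, so a step of similar size is expected. One step cannot settle the direction, and a lower number is only a tentative expectation. The expected change is a 2.4-fold lower number from compound 2 to compound 3 (0.38 log units; beyond the scatter) in this estimate. For compound 3 the estimated value is 500 nM with a range from 100 nM to 2500 nM as its expected span.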

Compound 3, half-maximal inhibitory concentration: 60 nM
Compound 3: the middle estimate sits 8.3-fold (0.92 log units) above what was measured; measured number outside the range, below it.
By their numbers in this assay, from the lowest: compound 3; then compound 2; then compound 1.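

At this carbon, next to the ring nitrogen, the number proved far more sensitive to the group than the earlier step had shown: a 20-fold lower number from compound 2 to compound 3 (1.30 log units; beyond the scatter), and a 48-fold lower number from compound 1 to compound 3 (1.68 log units; beyond the scatter). Of the three groups seen here in this assay, only piperidin-3-yl brings a six-membered non-aromatic ring, and compound 3 has the lowest number. No evidence on the reason for this gain is available. On these data alone, whether the gain belongs to the ring or to its nitrogen stays open, and a cyclohexyl or piperidin-4-yl group at this carbon would help separate the two.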